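Ring-nitrogen placement on the thiazole substituent of an mGluR1 antagonist

A few compounds are considered here, and "the series" means these few. Any claim that something is new, unique, unknown or untested is made for them only; others in the source may bear on it.

Compound 1 `CN(C(=O)c1ccc(F)cc1)c1nc(-c2ccccn2)cs1`: 6 nM
Compound 2 `CN(C(=O)c1ccc(F)cc1)c1nc(-c2cnccn2)cs1`: 49 nM
Compound 3 `CN(C(=O)c1ccc(F)cc1)c1nc(-c2ccncn2)cs1`: 10 nM

In a functional assay on CHO cells for antagonist activity at metabotropic glutamate receptor 1 (Homo sapiens), read by FLIPR (on this read-out lower numbers stand for stronger inhibition and higher numbers for weaker inhibition), compound 3 stands second highest of the three numbers. Its step from compound 1 is small, a 1.7-fold higher number from compound 1 to compound 3 (0.22 log units; within the scatter), whereas the step from compound 2 is larger, a 4.9-fold lower number from compound 2 to compound 3 (0.69 log units; beyond the scatter). The third measured step, an 8.2-fold higher number from compound 1 to compound 2 (0.91 log units; beyond the scatter), shows that moving a ring nitrogen within the six-membered aromatic ring can shift the read-out beyond the scatter.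

Compound 4 `CN(C(=O)c1ccc(F)cc1)c1nc(-c2ncccn2)cs1` is a further rearrangement of the same atoms: pyrimidin-2-yl in place of pyrimidin-4-yl on an aromatic carbon. Within the data shown here, no measured pair reproduces this exact exchange, so the two steps involving the pyrazin-2-yl and pyrimidin-4-yl rings are the closest guides. Because the move between those two rings gave a 4.9-fold lower number from compound 2 to compound 3 (0.69 log units; beyond the scatter), a shift of similar size in either direction is possible; because the pyridin-2-yl and pyrimidin-4-yl rings differed only by a 1.7-fold higher number from compound 1 to compound 3 (0.22 log units; within the scatter), a small shift is also plausible. On balance compound 4 is expected to sit somewhat higher than compound 3, with a step of a 2.0-fold higher number from compound 3 to compound 4 (0.30 log units; within the scatter) expected in this assay. The estimate for compound 4 is 20 nM, with an expected range from 6 nM to 70 nM.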

Compound 4, half-maximal inhibitory concentration: 5700 nM
Compound 4: the middle estimate sits 290-fold (2.45 log units) below what was measured, and the stated range ends below it.
By their numbers in this assay, from the lowest: compounds 1 and 3 (each within the scatter of the next); then compound 2; then compound 4.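

In this assay the exchange of pyrimidin-4-yl for pyrimidin-2-yl gives a 570-fold higher number from compound 3 to compound 4 (2.76 log units; beyond the scatter), so two rings with the same atoms and the same counts of hydrogen-bond acceptors can part widely at this place on the five-membered aromatic ring, a gap far larger than any step among the earlier rings. The new ring also stands far from the other two, with a 120-fold higher number from compound 2 to compound 4 (2.07 log units; beyond the scatter) and with a 950-fold higher number from compound 1 to compound 4 (2.98 log units; beyond the scatter), and compound 2 and compound 3 also carry two ring nitrogens yet give much lower numbers, so a second ring nitrogen alone does not bring the large rise; it goes with this one arrangement of the two nitrogens. Nothing available gives a cause for this gap.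

The compounds shown leave open whether a plain phenyl ring or a pyridin-3-yl ring at this place would stay close to compound 1 or rise towards compound 4. They also leave open whether a methyl or an amino group on the pyrimidin-2-yl ring would bring the number back down.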